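Lengthening the Oxygen-Linked Group in Compound 3

The source may hold more compounds than are shown below. What is called first, only, known or untested is meant among the compounds shown, and "the series" means these compounds.

The compounds measured so far:
Compound 1 `CCCn1ccc2cc(-c3cccnc3)cc(Cl)c2c1=O` gives 631 nM in a functional assay on CHO cells for agonist activity at metabotropic glutamate receptor 2 (Homo sapiens), read by GTPgammaS binding; on this read-out lower numbers stand for an effect already at smaller amounts and higher numbers for an effect only at larger amounts of compound.
Compound 2 `CCCn1ccc2cc(-c3ccc(N(C)C)nc3)cc(Cl)c2c1=O` gives 5010 nM in this assay.
Compound 3 `CCCn1ccc2cc(-c3ccc(Oc4ccccc4)nc3)cc(Cl)c2c1=O` gives 501 nM in this assay.

All three share one core and differ only in the group on an aromatic carbon of the attached ring. Compound 3 has the lowest number of the three, but its gap to compound 1 is within the scatter, so the two cannot be ranked; only compound 2 stands apart, with a 10-fold lower number from compound 2 to compound 3 (1.00 log units; beyond the scatter). Putting phenoxy in place of hydrogen gave a 1.3-fold lower number from compound 1 to compound 3 (0.10 log units; within the scatter), a change too small to count.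

Compound 4 `CCCn1ccc2cc(-c3ccc(OCCc4ccccc4)nc3)cc(Cl)c2c1=O` keeps the oxygen of compound 3 and changes what hangs from it: phenethyl in place of phenyl on an oxygen on an aromatic ring. For the measured compounds named here, no measured step alters the group on this oxygen, so the nearest guide is the step from compound 1 to compound 3, in which adding the whole phenoxy group hardly moved the number. Growing that group further is therefore expected to leave the number roughly where it is, with the estimated step of a 1.3-fold higher number from compound 3 to compound 4 (0.10 log units; within the scatter) lying within the scatter. Compound 4 is estimated at 630 nM, in a range from 200 nM to 2000 nM.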

Compound 4, half-maximal effective concentration: 631 nM
Estimate against measurement, compound 4: 1.0-fold (0.00 log units) below, and the stated range covers the measured number.
By their numbers in this assay, from the lowest: compounds 3, 1 and 4 (each within the scatter of the next); then compound 2.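

Putting phenethyl in place of phenyl on an oxygen on an aromatic ring gives a 1.3-fold higher number from compound 3 to compound 4 (0.10 log units; within the scatter) in this assay, so the extra length between the oxygen and the phenyl ring has no readable effect on this number. The comparison with the unsubstituted compound points the same way: adding the whole oxygen-linked group gives no change at the digits printed from compound 1 to compound 4 (within the scatter), so both phenoxy and the longer phenethyloxy are accommodated here without a difference that can be read from hydrogen. Phenethyloxy in place of dimethylamino gives a 7.9-fold lower number from compound 2 to compound 4 (0.90 log units; beyond the scatter), which leaves compound 2 as the only one of the four that stands apart, with the other three forming a single group within the scatter of one another.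

The compounds shown leave open whether this tolerance continues with a still longer chain on the oxygen, such as phenylpropyl, or with an amine or a carboxylic acid at the far end of the chain in place of the phenyl ring. Nothing available here gives a reason why dimethylamino stands apart from the oxygen-linked groups.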